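Aryl urea series: cytotoxicity notes toward compound 4

A few compounds are considered here, and "the series" means these few. Any claim that something is new, unique, unknown or untested is made for them only; others in the source may bear on it.

Measured so far in an ADME assay on BJ cells (Homo sapiens) for cytotoxicity, with a stated time of 72 h; on this read-out lower numbers stand for an effect already at smaller amounts and higher numbers for an effect only at larger amounts of compound:

compound 1 `COc1cccc(NC(=O)Nc2cc(C)nc3ccccc23)c1` gives 27000 nM.
compound 2 `Cc1cc(NC(=O)Nc2ccc(Cl)cc2)c2ccccc2n1` is reported only as a limit of the assay, > 25000 nM.
compound 3 `Cc1cc(NC(=O)Nc2cccc(Cl)c2)c2ccccc2n1` is reported only as a limit of the assay, > 25000 nM.

Two steps join these three. The first, a step that the two limits leave unreadable from compound 2 to compound 3, cannot be sized: the same holds for the second, a step that the limit leaves unreadable from compound 3 to compound 1, owing to the limit of > 25000 nM in this assay, at which 2 of the 3 values shown sit. The cores of compound 2 and compound 3 differ by 4-chlorophenyl in place of 3-chlorophenyl on an amide-type nitrogen.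

The change taken from compound 3 to compound 1 is methoxy in place of chloro on an aromatic carbon. The unmeasured compound 4 `COc1ccc(NC(=O)Nc2cc(C)nc3ccccc23)cc1` stands to compound 2 by the same kind of change, (methoxy in place of chloro on an aromatic carbon). Around the place the two are not identical: in compound 1 the entering group sits meta to a large group, in compound 4 para to a large group.

Within the data shown here, what can be expected of compound 4 rests on compound 1 alone, since compound 1 is the only member with a readable number, 27000 nM. The other two members are reported only as limits of the assay. The expected step is a step that the limit leaves unreadable from compound 2 to compound 4, an estimate that treats compound 4 as falling where compound 1 falls. Compound 4 is thus estimated at 30000 nM in this assay, expected to lie between 12000 nM and 80000 nM, with a real chance that the assay reports only a limit for it as well.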

Compound 4, half-maximal effective concentration: > 25000 nM
Compound 4: no number, only a limit (the forecaster's own chance of this, stated with the estimate: 50%); the middle value does not contradict the limit.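

No new step can be read in this assay: compound 2 and compound 4 are both reported only as limits, so the change between them has no readable size because of the limit: the limit of > 25000 nM in this assay, at which 3 of the 4 values shown sit.

The compounds shown leave open whether methoxy in place of chloro on an aromatic carbon shifts the read-out in this assay at all, and where compound 2, compound 3 and compound 4 lie relative to compound 1.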